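Amide nitrogen substituent change on the shared core

The compounds below may be only part of what the source reports. "The series", "measured", "known", "first", "only" and "open" are said of these compounds alone.

Compound 1 `O=C(O)CCc1cccc2c1B(O)OC2` is the free acid; in a functional assay on MDA-MB-231 cells (Homo sapiens) for antiproliferative activity, read by MTT assay, with a stated time of 72 h (a lower number here means a stronger inhibitor, a higher number a weaker inhibitor), compound 1 gives only a limit of the assay, > 100000 nM. Compound 2 `CCNC(=O)CCc1cccc2c1B(O)OC2` is its ethylamide; in this assay compound 2 also gives only a limit, > 100000 nM. The step that the two limits leave unreadable from compound 1 to compound 2 therefore cannot be read, because both values sit at the limit of > 100000 nM in this assay, at which 2 of the 2 values shown sit. Compound 3 `CC(C)(C)NC(=O)CCc1cccc2c1B(O)OC2` differs from compound 2 in one place: tert-butyl in place of ethyl on an amide-type nitrogen. For the measured compounds named here, the only measured step is the unreadable one between the acid and the ethylamide; no measured step touches the amide nitrogen substituent itself, so there is no basis to expect a move off the limit. Compound 3 is expected to remain at the limit, with a step that the limit leaves unreadable from compound 2 to compound 3 expected to be none beyond the scatter. The estimate for compound 3 in this assay is 150000 nM, with a range from 50000 nM to 500000 nM.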

Compound 3, half-maximal inhibitory concentration: > 100000 nM
Compound 3: a limit, no number (the forecaster's own chance of this, stated with the estimate: 85%); the middle value is on the limit's open side.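

Compound 3 gives only a limit in this assay, so its steps from compound 1 and compound 2 cannot be read: the limit of > 100000 nM in this assay, at which 3 of the 3 values shown sit.

The compounds shown leave open whether any amide nitrogen substituent on the shared core gives a value that is not a limit.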